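The source may hold more compounds than are shown below. What is called first, only, known or untested is meant among the compounds shown, and "the series" means these compounds.

Compound 1 `CCCCOC(=O)c1cccc(-c2cc(C(=O)Nc3ccncc3)ccc2CN)c1`: 0.367 h
Compound 2 `CC(N)c1ccc(C(=O)Nc2ccncc2)cc1-c1ccc(F)cc1`: > 2 h

Within the data shown here, in an ADME assay on a cell-free system (plasma, Homo sapiens) for metabolic stability, read by LC-MS (on this read-out lower numbers stand for a shorter-lived compound and higher numbers for a longer-lived compound), compound 1 gives 0.367 h, the only exact number available so far. Compound 2 sits at > 2 h, which is a limit of the assay and not a number.

Compound 3 `CCCOC(=O)c1cccc(-c2cc(C(=O)Nc3ccncc3)ccc2CN)c1` differs from compound 1 in one place: hydrogen in place of methyl on a saturated chain carbon, three bonds along the chain from an oxygen next to a carbonyl group. This is hydrogen in place of methyl on a saturated chain carbon, three bonds along the chain from an oxygen next to a carbonyl group, so butyl becomes propyl.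

Among the measured compounds shown here, no measured pair of compounds shows what a single change of this kind does. The change is small, so no shift beyond the scatter is expected in this assay, and the expected result is a 1.2-fold higher number from compound 1 to compound 3 (0.09 log units; within the scatter). For compound 3 the estimated half-life is 0.45 h, with an expected range from 0.2 h to 1 h.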

Compound 3, half-life: 0.3 h
Estimate against measurement, compound 3: 1.5-fold (0.18 log units) above, and the stated range covers the measured number.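

In this assay, among these compounds, the change from butyl to propyl gives the first measured single step at this place on the chain, and it is a 1.2-fold lower number from compound 1 to compound 3 (0.09 log units; within the scatter). Removing this one methyl, three bonds along the chain from the oxygen next to a carbonyl group, therefore leaves the half-life within what repeated measurements of the same compound would give. Nothing measured here gives a reason for this result.

One step of a single carbon says little about larger changes to this chain. Still open, on these data alone, is whether a longer chain such as hexyl, a branched chain such as isopropyl, or a carboxylic acid in place of the whole chain and its neighbouring oxygen would give a half-life clearly different from that of compound 1.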